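Changing the acyl group on a shared nitro-halo azo core

The source may report more compounds than this note shows. Statements on the series, on what has been measured and on what is new or still open speak of the compounds shown alone.

Measured compounds:
- compound 1, `O=C(c1ccccc1)N(/N=N/c1ccc([N+](=O)[O-])cc1Br)c1ccc([N+](=O)[O-])cc1Br`: 1530 nM
- compound 2, `O=C(c1ccccc1C(F)(F)F)N(/N=N/c1ccc([N+](=O)[O-])cc1Br)c1ccc([N+](=O)[O-])cc1Br`: 13300 nM
- compound 3, `O=C(c1ccccc1F)N(/N=N/c1ccc([N+](=O)[O-])cc1Cl)c1ccc([N+](=O)[O-])cc1Cl`: 2350 nM

The three measured compounds share one core and differ in the acyl group and in the halogen on the two aromatic rings. In a functional assay on HeLa cells (Homo sapiens) for cytotoxicity, read by MTT assay, with a stated time of 72 h (on this read-out lower numbers stand for stronger inhibition and higher numbers for weaker inhibition), compound 3 gives 2350 nM, the second highest of the three numbers. Its nearest neighbour is compound 1, whose 1530 nM lies within the scatter of compound 3; the gap to compound 2, with 13300 nM, is beyond the scatter.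

Compound 4, `CC(=O)OCC(=O)N(/N=N/c1ccc([N+](=O)[O-])cc1Cl)c1ccc([N+](=O)[O-])cc1Cl`, has not yet been measured. It differs from compound 3 in one place: acetoxymethyl in place of 2-fluorophenyl on a carbonyl carbon.

For the measured compounds named here, the only step measured so far with a single change is an 8.7-fold higher number from compound 1 to compound 2 (0.94 log units; beyond the scatter), which altered the acyl group by adding a trifluoromethyl to the phenyl ring. The change to compound 4 also sits on the acyl group, but replaces the whole ring with a short chain, so that step bears on it only loosely. Going by the values given here, with no closer precedent, a modest weakening is expected for compound 4, with wide uncertainty: a 1.9-fold higher number from compound 3 to compound 4 (0.28 log units; within the scatter). Compound 4 is therefore estimated at 4500 nM, within a range of 1200 nM to 17000 nM.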

Compound 4, half-maximal inhibitory concentration: 350 nM
Beside the measured number, compound 4's estimate is 13-fold (1.11 log units) above it; measured number outside the range, below it.
By their numbers in this assay, from the lowest: compound 4; then compounds 1 and 3 (each within the scatter of the next); then compound 2.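

In this assay, the step of a 6.7-fold lower number from compound 3 to compound 4 (0.83 log units; beyond the scatter) shows that the group on the carbonyl carbon need not be an aromatic ring; every acyl group measured before compound 4 carried one. For the compounds shown here, the only earlier single change at this position, an 8.7-fold higher number from compound 1 to compound 2 (0.94 log units; beyond the scatter), went the other way, so changes to the acyl group can now be seen to move the number in either direction. Acetoxymethyl enters with no ring and with hydrogen-bond acceptors where 2-fluorophenyl has none, but no measurement here gives a reason for the drop.

The compounds shown do not separate the loss of the ring from the arrival of the acetoxymethyl group, a question that a plain methyl, a hydroxymethyl or a methoxymethyl on the carbonyl carbon, or a longer chain ending in an ester, would bear on. They also leave open whether acetoxymethyl gives a similar step on the core of compound 1, which carries bromine, as it appears here only with chlorine on the two aromatic rings.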